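Cyano in Place of Bromo: Expectations for Compound 4

The source may hold more compounds than are shown below. What is called first, only, known or untested is meant among the compounds shown, and "the series" means these compounds.

Of the compounds shown here, three sharing one core have been tested in a functional assay on the whole organism for inhibition, with Rattus norvegicus as the target, at a dose of 30 mg/kg; on this read-out higher numbers stand for more inhibition at the one dose given (going by the name of the read-out) and lower numbers for less inhibition. Compound 1 `Cc1ccc(-c2nc3cccnc3o2)cc1` gives 0%, compound 2 `COc1ccc(Br)c(-c2nc3ncccc3o2)c1` gives 8% and compound 3 `Brc1ccccc1-c1nc2cccnc2o1` gives 31%. On these numbers compound 2 sits within the scatter of compound 1, while the value of compound 3 stands beyond that scatter, higher than the value of compound 2. Compound 4 `COc1ccc(C#N)c(-c2nc3ncccc3o2)c1` has not been measured; it differs from compound 2 by cyano in place of bromo on an aromatic carbon. Within the data shown here, no pair of measured compounds shows this change, so nothing in this assay tells its effect. The step is expected to be small, with a number 4 percentage points higher from compound 2 to compound 4 (within the scatter) estimated, not beyond the scatter. Compound 4 is therefore expected to give 12%, in a range from 0% to 35%.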

Compound 4, a percentage reported as inhibition, in the whole organism at one dose (the size of the read-out at that dose, not a potency): 3%
Beside the measured number, compound 4's estimate is 9 percentage points above it; the measured number falls inside the stated range.
By their numbers in this assay, from the lowest: compounds 1, 4 and 2 (each within the scatter of the next); then compound 3.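

Among these compounds, the step of a number 5 percentage points lower from compound 2 to compound 4 (within the scatter) in this assay gives the first direct reading of cyano in place of bromo on this aromatic carbon, ortho to a group of 9 heavy atoms and para to a methoxy group. At this position, on this read-out, the two groups cannot be told apart. The data offer no explanation for this result.
From the compounds shown here alone, whether an amine or a carboxylic acid on this carbon would move the value beyond the scatter remains open. Going by these compounds, it is also open whether cyano in place of bromo would read the same on compound 3, which lacks the methoxy group.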